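This account rests on a few compounds, and the source may have more. Where it says the series, first, only, none or still open, it means among the compounds named here.

The read-out here is an ADME assay (liver) for metabolic stability, with Liver microsome (Homo sapiens) as the target, read by LC-MS, using microsomes and NADPH, with a stated time of 5 min, at 37 degrees C; on this read-out higher numbers stand for fast clearance and lower numbers for slow clearance. Compound 1, with the structure `CCn1c([C@@H](C)NS(=O)(=O)c2ccc(Cl)cc2)nc2ccccc21`, gives only a limit in this assay, reported as > 100 mL.min-1.g-1. For the measured compounds named here, compound 2, with the structure `CCn1c([C@@H](C)NS(=O)(=O)c2ccc(F)cc2)nc2ccc(C(F)(F)F)cc21`, gives 26 mL.min-1.g-1 in this assay, and this is the only actual number among the two measured compounds, since the other value is the limit of > 100 mL.min-1.g-1 in this assay, at which 1 of the 2 values shown sits.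

The next compound, compound 3, has the structure `CCn1c([C@@H](C)NS(=O)(=O)c2cn(C)c(C)n2)nc2ccc(C(F)(F)F)cc21`. Compared with compound 2, the change is 1,2-dimethyl-1H-imidazol-4-yl in place of 4-fluorophenyl on a sulfonyl sulfur. No measured pair among these compounds shows what such a change does in this assay, so the step can only be estimated.

The step from compound 2 to compound 3 is expected to be a 1.7-fold lower number from compound 2 to compound 3 (0.24 log units; within the scatter), a modest move towards slower clearance that may not reach beyond the usual scatter. Compound 3 is therefore estimated to give 15 mL.min-1.g-1 in this assay, with a plausible range from 5 mL.min-1.g-1 to 40 mL.min-1.g-1.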

Compound 3, intrinsic clearance in microsomes: 43 mL.min-1.g-1
The estimate for compound 3 lay 2.9-fold (0.46 log units) below the measured number; measured number above the stated range.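

In this assay, putting 1,2-dimethyl-1H-imidazol-4-yl in place of 4-fluorophenyl on a sulfonyl sulfur gives a 1.7-fold higher number from compound 2 to compound 3 (0.22 log units; within the scatter), so the two numbers cannot be told apart. For the compounds shown here, this is the first pair here that differs in one place only, and it shows that a five-membered aromatic ring with two hetero atoms can replace a six-membered ring of carbon only at this position without a change beyond the scatter. Nothing measured here explains why the two compounds read alike.

As far as these compounds go, whether a saturated amine such as morpholine, or a plain alkyl chain, on the same sulfonyl sulfur would move the number beyond the scatter remains open. Steps from compound 1 to the other two cannot be read, since it differs from each of them in more than one place.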